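The source may report more compounds than this note shows. Statements on the series, on what has been measured and on what is new or still open speak of the compounds shown alone.

Of the compounds shown here, two have so far been measured in a functional assay on ASPC1 cells (Homo sapiens) for inhibition, read by MTT assay, with a stated time of 72 h; a higher number here means a weaker inhibitor of growth, a lower number a stronger inhibitor of growth. Compound 1, `O=S(=O)(NCCCNCc1ccc(Cl)c(Cl)c1)c1cc(C(F)(F)F)cc(C(F)(F)F)c1`, gives 2800 nM in this assay. Compound 2, `O=S(=O)(NCCCNCc1ccccc1)c1cc(C(F)(F)F)cc(C(F)(F)F)c1`, gives 13000 nM in this assay. Of the two numbers, compound 2 stands at the higher one, which marks it as the weaker growth inhibitor of the pair. Among the measured compounds shown here, the single step between measured compounds, a 4.6-fold higher number from compound 1 to compound 2 (0.67 log units; beyond the scatter), comes from putting phenyl in place of 3,4-dichlorophenyl on the saturated chain carbon bound to the amine nitrogen.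

Compound 3, `COc1cccc(CNCCCNS(=O)(=O)c2cc(C(F)(F)F)cc(C(F)(F)F)c2)c1`, is still unmeasured. It differs from compound 2 by methoxy in place of hydrogen on an aromatic carbon. For the measured compounds named here, the only measured step that speaks to this change is a 4.6-fold higher number from compound 1 to compound 2 (0.67 log units; beyond the scatter), which showed that a substituted ring at this position gave the lower number. That step concerned chlorine rather than methoxy, so it offers only a loose guide. A modest step toward a lower number is expected, a 1.6-fold lower number from compound 2 to compound 3 (0.21 log units; within the scatter). Compound 3 is therefore estimated at 8000 nM, with a range from 3000 nM to 20000 nM.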

Compound 3, concentration for 50% growth inhibition: 3800 nM
For compound 3 the middle estimate is 2.1-fold (0.32 log units) above the measured one; measured number inside the range.
By their numbers in this assay, from the lowest: compounds 1 and 3 (each within the scatter of the next); then compound 2.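

In this assay, the step to the methoxy compound, a 3.4-fold lower number from compound 2 to compound 3 (0.53 log units; beyond the scatter), shows that the unsubstituted phenyl ring responds to a single methoxy on an aromatic carbon, a change beyond the scatter, whereas the earlier pair had shown a ring effect only for 3,4-dichlorophenyl. The comparison of the two substituted rings, a 1.4-fold higher number from compound 1 to compound 3 (0.13 log units; within the scatter), lies within the scatter, so 3-methoxyphenyl and 3,4-dichlorophenyl cannot be told apart here, and both compound 1 and compound 3 stand clear of compound 2, which carries the plain phenyl. No measurement at hand accounts for this response of the ring to either substitution.

The compounds shown leave open whether a hydroxy group, an ethoxy group or a single chlorine on the same aromatic carbon would give a number like that of compound 3. They also leave open whether the link between ring substitution and growth inhibition would hold with a longer chain than the one shared by all three compounds, or with a carboxylic acid on the ring in place of the methoxy.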